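A few compounds are considered here, and "the series" means these few. Any claim that something is new, unique, unknown or untested is made for them only; others in the source may bear on it.

In a functional assay on NCI-H1975 cells (Homo sapiens) for inhibition, read by MTT assay, with a stated time of 72 h (on this read-out lower numbers stand for stronger inhibition and higher numbers for weaker inhibition), two compounds built on the shared core have been measured so far. Compound 1 `CCN1CCN(c2cc(C(F)(F)F)nc(SCc3ccc(C(F)(F)F)cc3)n2)CC1` gives 15000 nM, and compound 2 `FC(F)(F)c1ccc(CSc2nc(Sc3ccccn3)cc(C(F)(F)F)n2)cc1` gives 23900 nM. These two numbers lie within the scatter of each other, so the data cannot separate compound 2 from compound 1. Still unmeasured is compound 3 `FC(F)(F)c1ccc(CSc2nc(SC3=NCCS3)cc(C(F)(F)F)n2)cc1`, which differs from compound 2 in one place: a group of 5 heavy atoms (3 carbon, 1 nitrogen, 1 sulfur; one five-membered non-aromatic ring with 2 hetero atoms) in place of a group of 6 heavy atoms (5 carbon, 1 nitrogen; one six-membered aromatic ring with 1 hetero atom), on a sulfur. The ring on that sulfur is thus exchanged, while the rest of the molecule stays the same. Among the compounds with values here, only one measured step bears on this change, namely a 1.6-fold higher number from compound 1 to compound 2 (0.20 log units; within the scatter). Within the data shown here, it stays within the scatter, but it concerns a different exchange, made on an aromatic carbon, and no measurement yet tests any other group on this sulfur. The evidence is therefore thin, and no step beyond the scatter is expected in this assay. The estimated change is a 1.2-fold lower number from compound 2 to compound 3 (0.08 log units; within the scatter). For compound 3 the expected value is 20000 nM, with an estimated range from 8000 nM to 50000 nM.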

Compound 3, half-maximal inhibitory concentration: 24200 nM
Compound 3: middle estimate off by 1.2-fold (0.08 log units), on the low side, and the stated range covers the measured number.
By their numbers in this assay, from the lowest: compounds 1, 2 and 3 (each within the scatter of the next).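

In this assay, within the data shown here, the exchange of pyridin-2-yl for the five-membered non-aromatic ring with 2 hetero atoms gives a 1.0-fold higher number from compound 2 to compound 3 (0.01 log units; within the scatter), the first reading of a change on the sulfur itself rather than on the aromatic carbon. Read against the 4-ethylpiperazin-1-yl group, the same ring with its sulfur linker gives a 1.6-fold higher number from compound 1 to compound 3 (0.21 log units; within the scatter), so all three groups now tested at this place leave the compounds indistinguishable, whether the group is aromatic or non-aromatic and whether it is attached through sulfur or not. No supporting measurement bears on why these groups read alike.

The compounds shown leave open whether any group at this place can produce a step beyond the scatter, for example a primary amine, a morpholine, a carboxylic acid or a longer alkyl chain on the sulfur. They also leave open whether the rest of the molecule, held the same throughout, matters more for this read-out, as would be tested by replacing the trifluoromethyl group on the shared core with a hydrogen or a methyl group.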